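The compounds below may be only part of what the source reports. "The series", "measured", "known", "first", "only" and "open" are said of these compounds alone.

Three compounds have been measured in a functional assay on HCT-15 cells (Homo sapiens) for antiproliferative activity, read by sulforhodamine B assay; a higher number here means a weaker inhibitor of growth, a lower number a stronger inhibitor of growth:

Compound 1 `COc1cccc(OCCC(C)(C)C)c1C(=O)/C=C/c1ccc(O)cc1`: > 30000 nM (a limit of the assay)
Compound 2 `CC(C)(C)CCOc1cccc(O)c1C(=O)/C=C/c1ccc(C(=O)O)cc1`: 2170 nM
Compound 3 `CC(C)(C)CCOc1cccc(O)c1C(=O)/C=C/c1ccc(O)cc1`: 3430 nM

Compound 3 gives 3430 nM in this assay, and this lies within the scatter of compound 2 at 2170 nM. The value for compound 1 is a limit, so compound 3 can be compared with it only through the step below.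

The next compound is compound 4 `O=C(/C=C/c1ccc(O)cc1)c1c(O)cccc1OCC1CCCCC1`, which carries cyclohexyl in place of neopentyl on a saturated chain carbon bound to an oxygen on an aromatic ring. In other words, 3,3-dimethylbutoxy becomes cyclohexylmethoxy.

Two measured steps lead to compound 3. The first is an at least 8.7-fold lower number from compound 1 to compound 3 (0.94 log units; beyond the scatter), and it rests on the limit: the limit of > 30000 nM in this assay, at which 1 of the 3 values shown sits. The second is a 1.6-fold higher number from compound 2 to compound 3 (0.20 log units; within the scatter). Both change other groups and keep the 3,3-dimethylbutoxy group, so neither measures a change in this chain. Going by the values given here, with no measured step on this chain, the expectation starts from compound 3 at 3430 nM and assumes no change beyond the scatter in this assay. The expected step is a 1.1-fold lower number from compound 3 to compound 4 (0.06 log units; within the scatter). For compound 4 the estimated value is 3000 nM, with an expected range from 1200 nM to 8000 nM.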

Compound 4, concentration for 50% growth inhibition: > 30000 nM
Compound 4: a limit, no number; the forecaster's own chance of this, stated with the estimate: 5%; at least 10-fold (1.00 log units) between middle value and limit.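

In this assay, going by these compounds alone, the change from 3,3-dimethylbutoxy to cyclohexylmethoxy is the first measured change in this chain, and it gives an at least 8.7-fold higher number from compound 3 to compound 4 (0.94 log units; beyond the scatter). Compound 4 gives > 30000 nM, which is a limit of the assay and not a number, so the step has a floor but no measured size: the limit of > 30000 nM in this assay, at which 2 of the 4 values shown sit.

The earlier steps shown here all kept the 3,3-dimethylbutoxy group and could say nothing about this place, whereas this one shows that exchanging neopentyl for cyclohexyl on the saturated chain carbon bound to an oxygen on an aromatic ring is enough to move the number beyond the scatter, with no hydrogen-bond donor or acceptor entering or leaving.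

The compounds shown leave open whether the ring itself or some other feature of this particular group accounts for the step, as only these two groups stand at this place. From the compounds shown here alone, how a phenyl ring in place of cyclohexyl, a longer chain or an amine at the end of the chain would read in this assay remains open, as does whether cyclohexylmethoxy would give the same result alongside the carboxylic acid of compound 2.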